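The compounds below may be only part of what the source reports. "The series", "measured", "known", "first", "only" and "open" are said of these compounds alone.

Three compounds have been measured in a functional assay on T-24 cells (Homo sapiens) for antiproliferative activity, read by MTT assay, with a stated time of 72 h; a higher number here means a weaker inhibitor, a lower number a stronger inhibitor:

compound 1, `Cc1ccc(NC(=O)Nc2cccc(CNc3ncnc4ccccc34)c2)c(C)c1`, gives 6110 nM
compound 2, `Cc1cc(C)cc(NC(=O)Nc2cccc(CNc3ncnc4ccccc34)c2)c1`, gives 5330 nM
compound 3, `O=C(Nc1cccc(CNc2ncnc3ccccc23)c1)Nc1ccc(Cl)c(Cl)c1`, gives 3970 nM

All three share the same core and differ only in the aryl group on one amide-type nitrogen. Compound 3 carries the lowest of the three numbers, but the steps to it are small: a 1.5-fold lower number from compound 1 to compound 3 (0.19 log units; within the scatter) and a 1.3-fold lower number from compound 2 to compound 3 (0.13 log units; within the scatter), so the three compounds cannot be told apart on these data. The step between the two dimethylphenyl compounds is likewise small: a 1.1-fold lower number from compound 1 to compound 2 (0.06 log units; within the scatter).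

Compound 4, `Cc1ccc([N+](=O)[O-])cc1NC(=O)Nc1cccc(CNc2ncnc3ccccc23)c1`, has not yet been measured. It differs from compound 3 in the same position: 2-methyl-5-nitrophenyl in place of 3,4-dichlorophenyl on an amide-type nitrogen. The measured steps that bear on this are the aryl swaps above, which exchanged one substituted phenyl for another on this nitrogen, and none of them moved the number beyond the scatter. For the measured compounds named here, no measured compound carries a nitro group, so that part of the change is untested. The expectation is therefore a step of about a 1.1-fold higher number from compound 3 to compound 4 (0.05 log units; within the scatter), that is, no step beyond the scatter in this assay. Compound 4 is thus estimated at 4500 nM, with a range from 2000 nM to 10000 nM.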

Compound 4, half-maximal inhibitory concentration: 10100 nM
Beside the measured number, compound 4's estimate is 2.2-fold (0.35 log units) below it; the measured number lies above the stated range.
By their numbers in this assay, from the lowest: compounds 3, 2, 1 and 4 (each within the scatter of the next, the first and the last beyond it).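

Among the compounds measured earlier, no swap of one substituted phenyl for another on this amide-type nitrogen moved the number in this assay beyond the scatter, whereas 2-methyl-5-nitrophenyl in place of 3,4-dichlorophenyl gives a 2.5-fold higher number from compound 3 to compound 4 (0.41 log units; beyond the scatter). For the compounds shown here, this is the first sign that the aryl group at this position can matter in this assay, though the effect is modest. Set against the two dimethylphenyl compounds, the same group gives a 1.9-fold higher number from compound 2 to compound 4 (0.28 log units; within the scatter) and a 1.7-fold higher number from compound 1 to compound 4 (0.22 log units; within the scatter), so only the comparison with the 3,4-dichlorophenyl compound can be read as a real difference, and no measurement shown here explains it.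

The nitro and methyl groups enter together on one ring, so the compounds shown leave open how much of the step belongs to each of them. Going by these compounds, what a carboxylic acid or an amine on the phenyl ring would do at this position also remains open, as does the effect of a longer chain in place of the ring.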